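This account rests on a few compounds, and the source may have more. Where it says the series, first, only, none or still open, it means among the compounds named here.

In a functional assay on DU-145 cells (Homo sapiens) for inhibition, read by trypan blue exclusion, with a stated time of 96 h (a higher number here means a weaker inhibitor of growth, a lower number a stronger inhibitor of growth), compound 1 (`Cc1ccc(CS(=O)(=O)/C(=C/c2ccc(Br)cc2)C(=O)c2ccc(Cl)cc2)cc1`) gives 25000 nM, compound 2 (`CSc1ccc(/C=C(\C(=O)c2ccc(Cl)cc2)S(=O)(=O)Cc2ccc(C)cc2)cc1`) gives 10000 nM and compound 3 (`Cc1ccc(CS(=O)(=O)/C(=C/c2cccc(Cl)c2Cl)C(=O)c2ccc(Cl)cc2)cc1`) gives 1000 nM. Compound 3 therefore holds the lowest number of the three, and its steps to both others lie beyond the scatter.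

Compound 4 (`Cc1ccc(CS(=O)(=O)/C(=C/c2c[nH]c3ccccc23)C(=O)c2ccc(Cl)cc2)cc1`) has not yet been measured. Its difference from compound 3 lies in one place: 1H-indol-3-yl in place of 2,3-dichlorophenyl on a double-bonded chain carbon bound to a double-bonded chain carbon. In words, 1H-indol-3-yl stands in place of 2,3-dichlorophenyl on a double-bonded chain carbon bound to a double-bonded chain carbon.

Among the compounds with values here, three measured steps concern this same part of the series. The large 25-fold lower number from compound 1 to compound 3 (1.40 log units; beyond the scatter) and the modest 10-fold lower number from compound 2 to compound 3 (1.00 log units; beyond the scatter) both bring in 2,3-dichlorophenyl. The smaller 2.5-fold lower number from compound 1 to compound 2 (0.40 log units; beyond the scatter) changes only the group on the aromatic ring. In both steps that bring it in, 2,3-dichlorophenyl gives the lower number, so its departure points towards a higher number. Within the data shown here, no measured compound carries 1H-indol-3-yl, so the size of the change remains uncertain.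

A modest rise in this assay is expected, smaller than the largest measured step. The expected change is a 5.0-fold higher number from compound 3 to compound 4 (0.70 log units; beyond the scatter). For compound 4 the estimated value is 5000 nM, with an expected range of 1200 nM to 20000 nM.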

Compound 4, concentration for 50% growth inhibition: 25000 nM
The estimate for compound 4 lay 5.0-fold (0.70 log units) below the measured number; measured number outside the range, above it.
By their numbers in this assay, from the lowest: compound 3; then compound 2; then compounds 1 and 4 (each within the scatter of the next).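

In this assay, 1H-indol-3-yl does not hold the level reached with 2,3-dichlorophenyl on the double-bonded chain carbon: the change gives a 25-fold higher number from compound 3 to compound 4 (1.40 log units; beyond the scatter), a step of the same size as the one separating the 4-bromophenyl and 2,3-dichlorophenyl compounds. The same replacement gives a 2.5-fold higher number from compound 2 to compound 4 (0.40 log units; beyond the scatter) against 4-(methylsulfanyl)phenyl, while against 4-bromophenyl it gives no change at the digits printed from compound 1 to compound 4 (within the scatter), so the new group offers no advantage over either para-free comparison in the series. Among the four groups now compared at this place, only 2,3-dichlorophenyl gives a low number, and bringing in a five-membered aromatic ring with a hydrogen-bond donor does not recover it.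

No measurement at hand accounts for these differences. On these data alone, it remains open whether the low number requires both chlorine atoms of 2,3-dichlorophenyl, and how a 3-chlorophenyl, a 2,3-dimethylphenyl or a pyridinyl group would compare at this place on the same core.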